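This account rests on a few compounds, and the source may have more. Where it says the series, first, only, none or still open, it means among the compounds named here.

Compound 1 `O=C(N1CCC(F)CC1)N1CC(c2nc(-c3cccc(Cl)c3)no2)C1` gives 990 nM in an assay on HEK293 cells for positive allosteric modulation of metabotropic glutamate receptor 5 (Homo sapiens), read by FLIPR; a lower number here means that less compound is needed, a higher number that more compound is needed for the effect.
Compound 2 `CC1CCN(C(=O)N2CC(c3nc(-c4cccc(Cl)c4)no3)C2)C1` gives > 10000 nM in this assay.

The number for compound 2 is only a limit of this assay, not a measured value, so compound 2 sits at the weak edge of what was measured (the limit of > 10000 nM in this assay, at which 1 of the 2 values shown sits). Compound 3 `CC1CCN(C(=O)N2CC(c3nc(-c4cccc(Cl)c4)no3)C2)CC1` differs from compound 2 by 4-methylpiperidin-1-yl in place of 3-methylpyrrolidin-1-yl on a carbonyl carbon. Among the measured compounds shown here, the one measured step that bears on this change is an at least 10-fold higher number from compound 1 to compound 2 (1.00 log units; beyond the scatter), where a six-membered ring gave way to a five-membered one and potency fell. Restoring a six-membered ring in compound 3 is therefore expected to win part of that back, a step of an at least 3.3-fold lower number from compound 2 to compound 3 (0.52 log units; beyond the scatter). Compound 3 is estimated at 3000 nM, within 800 nM to 15000 nM.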

Compound 3, half-maximal effective concentration: 865 nM
For compound 3 the middle estimate is 3.5-fold (0.54 log units) above the measured one; measured number inside the range.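

Replacing 3-methylpyrrolidin-1-yl with 4-methylpiperidin-1-yl on the carbonyl carbon gives an at least 11-fold lower number from compound 2 to compound 3 (1.06 log units; beyond the scatter), so the loss seen with compound 2 does not carry over to every methyl-bearing ring. Compound 2 carries only a limit, so this step has no fixed size: the limit of > 10000 nM in this assay, at which 1 of the 3 values shown sits. Methyl in place of fluoro on a saturated ring carbon gives a 1.1-fold lower number from compound 1 to compound 3 (0.06 log units; within the scatter), so the two compounds cannot be told apart.

On these data alone, whether ring size or the place of the methyl matters more stays open, and 3-methylpiperidin-1-yl could separate the two. As far as these compounds go, how a hydroxyl or an amine on that ring carbon would compare also remains open.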